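The source may hold more compounds than are shown below. What is called first, only, known or untested is meant among the compounds shown, and "the series" means these compounds.

Working notes on the series.

Compound 1 `OC[C@H]1O[C@@H](n2cnc3c(SCC4CCCCC4)ncnc32)[C@H](O)[C@@H]1O` carries a (cyclohexylmethyl)sulfanyl group on the shared core and gives, in an assay on isolated protein for binding affinity to Equilibrative nucleoside transporter 1 (Homo sapiens) (on this read-out higher numbers stand for weaker inhibition and lower numbers for stronger inhibition), 1550 nM. That is the lowest of the two numbers recorded; the nearest is compound 2 `CC(C)c1ccc(CSc2ncnc3c2ncn3[C@@H]2O[C@H](CO)[C@@H](O)[C@H]2O)cc1`, which in this assay gives 4790 nM. Among the measured compounds shown here, the one measured step, a 3.1-fold higher number from compound 1 to compound 2 (0.49 log units; beyond the scatter), consists of a six-membered aromatic ring of carbon only entering where a six-membered non-aromatic ring of carbon only stood.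

Compound 3 `OC[C@H]1O[C@@H](n2cnc3c(CSc4ccccc4F)ncnc32)[C@H](O)[C@@H]1O` has not been measured. It differs from compound 1 as follows: ((2-fluorophenyl)sulfanyl)methyl in place of (cyclohexylmethyl)sulfanyl on an aromatic carbon. The step from compound 1 to compound 2 is the only one that bears on this change, and it also brought in an aromatic ring for a saturated one, so a move toward weaker inhibition of similar size is expected, a 2.3-fold higher number from compound 1 to compound 3 (0.35 log units; beyond the scatter). For the measured compounds named here, the reversed order of sulfur and chain carbon has no measured counterpart, which widens the range. For compound 3 the expected value in this assay is 3500 nM, between 1200 nM and 10000 nM.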

Compound 3, half-maximal inhibitory concentration: 355 nM
Estimate against measurement, compound 3: 9.9-fold (0.99 log units) above; measured number outside the range, below it.
By their numbers in this assay, from the lowest: compound 3; then compound 1; then compound 2.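

In this assay, among the compounds shown here, ((2-fluorophenyl)sulfanyl)methyl in place of (cyclohexylmethyl)sulfanyl gives a 4.4-fold lower number from compound 1 to compound 3 (0.64 log units; beyond the scatter), so a change at this aromatic carbon of the shared core can also move the read-out toward stronger inhibition, which the earlier compounds did not show. Both steps from compound 1 bring in a six-membered aromatic ring of carbon only, yet a 3.1-fold higher number from compound 1 to compound 2 (0.49 log units; beyond the scatter) runs the opposite way, so among these compounds the aromatic ring alone does not set the direction. No measurement at hand accounts for the stronger inhibition of compound 3.

The step from compound 1 to compound 3 changes the order of sulfur and chain carbon, the ring and the fluorine together, and these compounds do not separate the three. Also open, from the compounds shown here alone, is how a longer chain between sulfur and ring, or an amine on the ring, would behave.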